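The source may hold more compounds than are shown below. What is called first, only, known or untested is meant among the compounds shown, and "the series" means these compounds.

Working notes on the series

Among the measured compounds shown here, compound 1 `CCSc1nc(NC(C)c2ccccc2)c2ncn([C@@H]3O[C@H](CO)[C@@H](O)[C@H]3O)c2n1` is the only member with a number so far: in a functional assay on a cell-free system (Platelet, plasma, Homo sapiens) for inhibition, with stated times of 1 min and 3 min (on this read-out higher numbers stand for weaker inhibition and lower numbers for stronger inhibition), compound 1 gives 197000 nM, a very weak result on this read-out. Compound 2 `CCCCN(CCCC)c1nc(SCC)nc2c1ncn2[C@@H]1O[C@H](CO)[C@@H](O)[C@H]1O` has no result in this assay; its entry is "not determined" (no result reported), so compound 2 stands nowhere on the numbers shown, and no comparison with compound 1 can be drawn from it.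

Compound 3 `CCSc1nc(NCc2ccccc2)c2ncn([C@@H]3O[C@H](CO)[C@@H](O)[C@H]3O)c2n1` is still to be measured in this assay. It follows from compound 2 by a single change, (benzylamino in place of dibutylamino on an aromatic carbon), on an aromatic carbon of the six-membered aromatic ring with two nitrogens, next to the ring nitrogen and meta to the ethylsulfanyl group.

For the measured compounds named here, with no number for compound 2, no step from compound 2 to compound 3 can be stated in this assay, and no direction can be given for it. The only anchor is the weak value of compound 1, and compound 3 shares the ethylsulfanyl group, the sugar and the fused core with compound 1. On that basis compound 3 is expected to sit in the same weak region, with an estimated value of 150000 nM in this assay, within a range from 40000 nM to 500000 nM, and a real chance that only a limit is reported.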

Compound 3, half-maximal inhibitory concentration: 176000 nM
Estimate against measurement, compound 3: 1.2-fold (0.07 log units) below; measured number inside the range.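

In this assay, hydrogen in place of methyl on the saturated chain carbon bound to an aromatic carbon and a nitrogen gives a 1.1-fold lower number from compound 1 to compound 3 (0.05 log units; within the scatter), so this methyl makes no readable difference on this read-out. Compound 3 also provides a second number for the series, and it shows that the weak result of compound 1 is not tied to that methyl: with or without it, the amine substituent on this aromatic carbon of the shared core gives a result in the same weak region. No supporting measurement bears on why the values stay at this level.

As far as these compounds go, with no number for compound 2, the exchange of dibutylamino for benzylamino cannot be read, so the effect of replacing the benzylamino group with a non-aromatic chain remains unknown. Also open, from the compounds shown here alone, is whether a plain amino group or a phenethylamino group in place of benzylamino, or a longer chain in place of ethylsulfanyl, would move the result out of this weak region.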